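Compound 2 and a 4-ethoxyphenyl swap

The source may hold more compounds than are shown below. What is called first, only, known or untested is meant among the compounds shown, and "the series" means these compounds.

In a functional assay on HCT-116 cells (Homo sapiens) for antiproliferative activity, read by MTT assay, with a stated time of 48 h (a lower number here means a stronger inhibitor, a higher number a weaker inhibitor), compound 1 (`COc1ccc(-c2cc3c(cn2)[nH]c(=O)n3-c2cc(OC)c(OC)c(OC)c2)cc1O`) gives 340 nM and compound 2 (`COc1ccc(-c2cc3c(cn2)[nH]c(=O)n3-c2cc(OC)c(OC)c(OC)c2)cn1`) gives 830 nM, the higher and therefore weaker of the two numbers. Compound 3 (`CCOc1ccc(-c2cc3c(cn2)[nH]c(=O)n3-c2cc(OC)c(OC)c(OC)c2)cc1`) has 4-ethoxyphenyl in place of 6-methoxypyridin-3-yl on an aromatic carbon. Among the measured compounds shown here, one measured step bears on this change, a modest one: a 2.4-fold higher number from compound 1 to compound 2 (0.39 log units; beyond the scatter). That step left a ring of carbon only, and compound 3 returns to such a ring, but with different groups on it. In this assay, the expected result is a small move to a lower number, a 1.8-fold lower number from compound 2 to compound 3 (0.27 log units; within the scatter). The estimate for compound 3 is 450 nM, with an expected range of 140 nM to 1400 nM.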

Compound 3, half-maximal inhibitory concentration: 6660 nM
Compound 3: the middle estimate sits 15-fold (1.17 log units) below what was measured; the measured number lies above the stated range.
By their numbers in this assay, from the lowest: compound 1; then compound 2; then compound 3.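

In this assay this position proves sensitive to what it carries: a ring of carbon only does not by itself bring back the number of compound 1, since 4-ethoxyphenyl in place of 6-methoxypyridin-3-yl gives an 8.0-fold higher number from compound 2 to compound 3 (0.90 log units; beyond the scatter). Set against 3-hydroxy-4-methoxyphenyl, the same group gives a 20-fold higher number from compound 1 to compound 3 (1.29 log units; beyond the scatter), the largest step among these compounds. No measurement here explains either step.

As far as these compounds go, compound 3 changes the ring and the ethoxy chain together, so the share of each stays open. A 4-methoxyphenyl group would separate them, and an amine on this ring remains untested territory among the compounds shown.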